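This account rests on a few compounds, and the source may have more. Where it says the series, first, only, none or still open, it means among the compounds named here.

Measured compounds of the series:

compound 1, `CN1CCN(C(=O)c2c(NC(=O)NS(=O)(=O)c3ccccc3)sc3c2CCCCC3)CC1`, 56200 nM
compound 2, `O=C(Nc1sc2c(c1C(=O)NNc1ccc(Cl)cc1)CCCCC2)NS(=O)(=O)c1ccccc1`, 12000 nM

Both values come from a functional assay on cells (Cancer cell lines, Homo sapiens) for inhibition, with a stated time of 48 h; on this read-out lower numbers stand for stronger inhibition of growth and higher numbers for weaker inhibition of growth. Among the measured compounds shown here, compound 2 holds the lowest number of the two; the only neighbour is compound 1, which is a 4.7-fold lower number from compound 1 to compound 2 (0.67 log units; beyond the scatter) away, a change made at the carbonyl carbon of the shared core. Compound 3, `CCCNC(=O)c1c(NC(=O)NS(=O)(=O)c2ccccc2)sc2c1CCCCC2`, is not yet measured in this assay. It differs from compound 2 in one place: propyl in place of (4-chlorophenyl)amino on an amide-type nitrogen. For the measured compounds named here, no measured pair shows this particular exchange, so the only step that bears on it is the one from compound 1 to compound 2, which shows that the group on the carbonyl carbon moves the number by a modest amount. The replacement of the (4-chlorophenyl)amino group, with its ring and its donor and acceptor, by a plain propyl chain is a different change again, and the direction cannot be read from compound 1 and compound 2 alone. A step of about the same size as the measured one, toward a higher number, is expected: a 2.1-fold higher number from compound 2 to compound 3 (0.32 log units; beyond the scatter). For compound 3 the estimate in this assay is 25000 nM, within 8000 nM to 80000 nM.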

Compound 3, concentration for 50% growth inhibition: 72500 nM
Estimate against measurement, compound 3: 2.9-fold (0.46 log units) below; measured number inside the range.
By their numbers in this assay, from the lowest: compound 2; then compounds 1 and 3 (each within the scatter of the next).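

In this assay, taking out (4-chlorophenyl)amino and putting in propyl on the amide-type nitrogen gives a 6.0-fold higher number from compound 2 to compound 3 (0.78 log units; beyond the scatter) and so measures this exchange directly. Propylamino in place of 4-methylpiperazin-1-yl on the carbonyl carbon gives a 1.3-fold higher number from compound 1 to compound 3 (0.11 log units; within the scatter) and does not separate these two groups, although one is an open chain and the other a ring. Among the three compounds, only compound 2 stands apart from the others, and it alone carries the six-membered aromatic ring of carbon only and the chlorine.

These compounds do not show whether the ring, the chlorine or the nitrogen that joins the ring to the amide-type nitrogen accounts for the lower number of compound 2, since all three leave together in the step to compound 3. An unsubstituted phenylamino group would separate the chlorine from the ring, and a benzyl group on the amide-type nitrogen would separate the ring from that joining nitrogen. No measurement at hand offers an explanation for either step.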